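A smaller amide substituent and its expected lipophilicity

The source may hold more compounds than are shown below. What is called first, only, known or untested is meant among the compounds shown, and "the series" means these compounds.

Compound 1 `CNC(=O)c1cc(C(=O)NCCC[C@H]2OC[C@H](N)CO2)cc2c1OC[C@H]2c1ccccc1`: 2.6
Compound 2 `CNC(=O)c1cc(C(=O)N[C@H]2C[C@@H]2C)cc2c1OC[C@@]2(C)c1ccccc1`: 4.7

In a physicochemical assay for lipophilicity, at pH 7.4 (on this read-out lower numbers stand for lower lipophilicity and higher numbers for higher lipophilicity), compound 1 gives 2.6, the lower of the two measured numbers, while compound 2 gives 4.7, a gap beyond the usual scatter. Compound 3 `CNC(=O)c1cc(C(=O)NC2CC2)cc2c1OC[C@H]2c1ccccc1` has not yet been measured. It differs from compound 1 in one place: a group of 3 heavy atoms (3 carbon; one three-membered non-aromatic ring of carbon only) in place of a group of 10 heavy atoms (7 carbon, 1 nitrogen, 2 oxygen; one six-membered non-aromatic ring with 2 hetero atoms), on an amide-type nitrogen. Going by the values given here, no measured pair shows a single change of this kind, so the size of the step is uncertain. The step expected from this change, a number 1.20 log units higher from compound 1 to compound 3 (beyond the scatter), is a rise well beyond the scatter. Compound 3 is estimated at 3.8, with a range from 3.2 to 4.4.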

Compound 3, distribution coefficient: 3.6
Beside the measured number, compound 3's estimate is 0.20 log units above it, and the stated range covers the measured number.
By their numbers in this assay, from the lowest: compound 1; then compound 3; then compound 2.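

In this assay, putting cyclopropyl in place of the larger ring-bearing group on the amide-type nitrogen gives a number 1.00 log units higher from compound 1 to compound 3 (beyond the scatter), the only single-place step shown at this position. The group that leaves holds nitrogen, oxygen and a hydrogen-bond donor, while cyclopropyl holds none of these, so several differences change together in this one swap. Nothing measured here explains the step. As far as these compounds go, a plain propyl chain and an aminopropyl chain on the same nitrogen remain open, and either could help show which part of the departing group goes with the step.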